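A few compounds are considered here, and "the series" means these few. Any claim that something is new, unique, unknown or untested is made for them only; others in the source may bear on it.

Three compounds share one core and differ only in the group on the carbonyl carbon at the end of the chain. In an assay on a protein complex for inhibition of CDK8/Cyclin C (Homo sapiens), with a stated time of 1 h (a higher number here means a weaker inhibitor, a lower number a stronger inhibitor), compound 1 `NC(=O)/C=C/c1ccncc1-c1ccc2ccccc2c1` gives 10.5 nM. Compound 2 `COC(=O)/C=C/c1ccncc1-c1ccc2ccccc2c1` gives 40.6 nM in this assay, and compound 3 `O=C(/C=C/c1ccncc1-c1ccc2ccccc2c1)NC1CC1` gives 40.1 nM. Compound 3 thus stands with the second highest number of the three: its number and that of compound 2 lie within the scatter of each other, while the step of a 3.8-fold higher number from compound 1 to compound 3 (0.58 log units; beyond the scatter) lies beyond it.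

Compound 4 `CN1CCN(C(=O)/C=C/c2ccncc2-c2ccc3ccccc3c2)CC1` is the next compound for this assay. 4-methylpiperazin-1-yl in place of cyclopropylamino on a carbonyl carbon Two measured steps bear on this change. The step of a 3.8-fold higher number from compound 1 to compound 3 (0.58 log units; beyond the scatter) shows that a larger group on the amide nitrogen gave a higher number, and the step of a 1.0-fold lower number from compound 2 to compound 3 (0.01 log units; within the scatter) shows that swapping one small group for another on the carbonyl carbon gave no step beyond the scatter. The new group is larger again and carries no hydrogen-bond donor, so the expected step is a 1.5-fold higher number from compound 3 to compound 4 (0.18 log units; within the scatter), at most a modest rise. Compound 4 is therefore estimated at 60 nM, in a range from 20 nM to 200 nM.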

Compound 4, half-maximal inhibitory concentration: 43.6 nM
For compound 4 the middle estimate is 1.4-fold (0.14 log units) above the measured one, and the stated range covers the measured number.
By their numbers in this assay, from the lowest: compound 1; then compounds 3, 2 and 4 (each within the scatter of the next).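

In this assay, the step of a 1.1-fold higher number from compound 3 to compound 4 (0.04 log units; within the scatter) and the step of a 1.1-fold higher number from compound 2 to compound 4 (0.03 log units; within the scatter) show that 4-methylpiperazin-1-yl on the carbonyl carbon sits level with both cyclopropylamino and methoxy, even though it is the largest of these groups. Hydrogen-bond donors do not separate these compounds either, as cyclopropylamino has one and 4-methylpiperazin-1-yl has none, so amino alone stands apart among the four groups, as the step of a 4.2-fold higher number from compound 1 to compound 4 (0.62 log units; beyond the scatter) confirms. No measurement here explains why these three different groups give such similar numbers.

Going by these compounds, it remains open whether methylamino on the carbonyl carbon would stay close to compound 1 or join compound 3. How a hydroxyl group, which would make the chain end a carboxylic acid, would compare is also unknown.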